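The source may hold more compounds than are shown below. What is called first, only, known or untested is meant among the compounds shown, and "the series" means these compounds.

Measured compounds: compound 1 `COc1cc(O)c(C(=O)c2cccc(F)c2)c(OC)c1` gives 81%; compound 2 `COc1cc(O)c(C(=O)c2ccccc2Br)c(OC)c1` gives 72%; compound 3 `COc1cc(OC)c(C(=O)c2ccccc2F)c(O)c1CN1CCCC1` gives 87%.

In a functional assay on THP-1 cells (Homo sapiens) for inhibition, read by ELISA, with stated times of 30 min and 24 h, tested at 10 uM (a higher number here means a stronger effect of the compound at the concentration tested, a lower number a weaker effect), compound 1 stands second of the three numbers; compound 3 lies six points higher and compound 2 nine points lower, both differences within the scatter, so the three read-outs cannot be ordered with confidence.

Compound 4 `COc1cc(OC)c(C(=O)c2cccc(F)c2)c(O)c1CN1CCCCC1` is not yet measured. It differs from compound 1 by (piperidin-1-yl)methyl in place of hydrogen on an aromatic carbon. The three measured compounds share one core carrying a substituted benzoyl group; compound 3 shows that a cyclic aminomethyl group at this carbon, with a different fluorophenyl, keeps the read-out at the upper end of the set, while compound 1 shows the bare carbon with the 3-fluorophenyl variant.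

Within the data shown here, no step between measured compounds is available, so the expected size comes only from these values. The account expects a step from compound 1 to compound 4 of a number 3 percentage points higher from compound 1 to compound 4 (within the scatter), that is, no change beyond the scatter. Compound 4 is therefore estimated at 84%, ranging from 72% to 94%.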

Compound 4, a percentage reported as activity, at one concentration (the size of the read-out at that concentration, not a potency): 87%
Beside the measured number, compound 4's estimate is 3 percentage points below it, and the stated range covers the measured number.
By their numbers in this assay, from the lowest: compounds 2, 1, 3 and 4 (each within the scatter of the next, the first and the last beyond it).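

In this assay, placing (piperidin-1-yl)methyl in place of hydrogen on the aromatic carbon ortho to a hydroxy group gives a number 6 percentage points higher from compound 1 to compound 4 (within the scatter) and so shows that the read-out stays level when this group enters at this position. The earlier compounds shown here could not show this, as no two of them differed in one place only. Nothing at hand accounts for the read-out staying level or ties it to any feature of the group.

Going by these compounds, it remains open whether an open-chain amine such as dimethylaminomethyl, or a carboxylic acid on a short chain, at this same carbon would keep the read-out in this range. A read-out at a single concentration also leaves open how these compounds would rank by potency.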